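Nitro in place of cyano on compound 1

The compounds below may be only part of what the source reports. "The series", "measured", "known", "first", "only" and "open" are said of these compounds alone.

compound 1 `COC(=O)c1ccc(NCc2cncn2Cc2ccc(C#N)cc2)cc1-c1ccccc1`: > 10000 nM in a toxicity assay on NIH3T3 cells (Mus musculus) for cytotoxicity, read by resazurin assay; on this read-out lower numbers stand for an effect already at smaller amounts and higher numbers for an effect only at larger amounts of compound
compound 2 `O=C(OC1CCCCC1)c1ccc(NCc2cncn2Cc2ccc(-c3ccccc3)cc2)cc1-c1ccccc1`: > 10000 nM in this assay
compound 3 `c1ccc(-c2ccc(Cn3cncc3CNc3ccc(-c4nc5ccccc5o4)c(-c4ccccc4)c3)cc2)cc1`: > 10000 nM in this assay

Each reading above is a limit of this assay and not a number. Compound 1 stands at that limit. Compound 2 stands at the same limit. Compound 3 stands at the same limit as well, so all three readings sit at one point (the limit of > 10000 nM in this assay, at which 3 of the 3 values shown sit). Among the compounds with values here, the single step between measured compounds that differ in one place, a step that the two limits leave unreadable from compound 2 to compound 3, runs between two limits and its size cannot be read; it also touches a different part of the shared core than the change considered here.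

Compound 4 `COC(=O)c1ccc(NCc2cncn2Cc2ccc([N+](=O)[O-])cc2)cc1-c1ccccc1` differs from compound 1 as follows: nitro in place of cyano on an aromatic carbon. Within the data shown here, no measured step bears on this change, and the one step available gives no readable size. The expectation therefore rests only on the position of compound 1 at the limit, and no step beyond the scatter is expected in this assay for compound 4. The step that is expected reads a step that the limit leaves unreadable from compound 1 to compound 4. Compound 4 is estimated to remain at the limit of this assay, around 15000 nM, expected between 8000 nM and 40000 nM.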

Compound 4, half-maximal effective concentration: > 10000 nM
Compound 4: no number, only a limit (the forecaster's own chance of this, stated with the estimate: 85%); the middle value does not contradict the limit.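

No new step can be read: compound 1 and compound 4 both stand at a limit and not at a number in this assay, and the size of the change from cyano to nitro cannot be read. The compounds shown leave open at what concentration, if any, an effect would appear in this assay, and whether these two groups differ there.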